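From carboxy to bromo on the shared core

A few compounds are considered here, and "the series" means these few. Any claim that something is new, unique, unknown or untested is made for them only; others in the source may bear on it.

Compound 1 `Cc1c(COc2cccc(OCC3CCOCC3)c2)[nH]c2ccc(C(=O)O)cc2c1=O`: >= 100000 nM (a limit)
Compound 2 `O=c1c(Cl)c(COc2cccc(OCC3CCOCC3)c2)[nH]c2ccccc12`: 2000 nM
Compound 3 `CCCCCCCCCc1[nH]c2ccccc2c(=O)c1C`: < 1000 nM (a limit)

All three compounds were read in a physicochemical assay for solubility, at pH 6.8; on this read-out higher numbers stand for higher solubility and lower numbers for lower solubility. For compound 1 there is only a limit and no number, (the limit of >= 100000 nM in this assay, at which 1 of the 3 values shown sits). Compound 3 is likewise held only as a limit, (the limit of < 1000 nM in this assay, at which 1 of the 3 values shown sits). Compound 2 alone has a measured number.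

Compound 4 `Cc1c(COc2cccc(OCC3CCOCC3)c2)[nH]c2ccc(Br)cc2c1=O` keeps the core of compound 1 and changes it in one place: bromo in place of carboxy on an aromatic carbon. This is bromo in place of carboxy on an aromatic carbon of a six-membered aromatic ring of carbon only, meta to a fused ring and para to a fused ring.

Going by the values given here, no two measured compounds differ in one place only, so the size of this change has not been seen directly. The nearest guide is compound 2, which also has no carboxy group and gives 2000 nM. On that basis a large fall in this assay is expected, and the estimated step is an at least 83-fold lower number from compound 1 to compound 4 (1.92 log units; beyond the scatter). The reading may well return only as a limit. Compound 4 is estimated at 1200 nM, with an expected range from 300 nM to 6000 nM.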

Compound 4, solubility: < 1000 nM
Compound 4: only a limit was reported; the forecaster's own chance of this, stated with the estimate: 45%; at least 1.2-fold (0.07 log units) between middle value and limit.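

Going by these compounds alone, until now no two measured compounds differed in one place, so the swap of carboxy for bromo on an aromatic carbon, meta to a fused ring and para to a fused ring, is the only change on the shared core whose size can be read in this assay, and it gives an at least 100-fold lower number from compound 1 to compound 4 (2.00 log units; beyond the scatter). Compound 1 is held at a limit, not a number: the limit of >= 100000 nM in this assay, at which 1 of the 4 values shown sits. Compound 4 is also held at a limit, not a number: the limit of < 1000 nM in this assay, at which 2 of the 4 values shown sit.

On these data alone, with a limit at both ends, the full size of this step stays unknown, and the pair cannot tell whether the departure of carboxy or the arrival of bromo accounts for it. Also open, as far as these compounds go, is where an amine or a nitrile on this same aromatic carbon would fall in this assay, relative to compound 1 and compound 4, and whether carboxy at this position would give a comparable step on a core carrying the chloro group of compound 2.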